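A few compounds are considered here, and "the series" means these few. Any claim that something is new, unique, unknown or untested is made for them only; others in the source may bear on it.

Notes on the series. Compound 1 `COC(c1cc(Cl)c2c(c1Cl)C(=O)N(Cc1c(C)cc(C)[nH]c1=O)CC2)C1CCOC1` has repeated measurements in a functional assay on KARPAS-422 cells (Homo sapiens) for antiproliferative activity, read by resazurin assay, with a stated time of 72 h (on this read-out lower numbers stand for stronger inhibition and higher numbers for weaker inhibition), where compound 1 gives 175 nM; 406 nM; 50 nM; 25 nM (4 entries), and the repeats spread out: the several entries of compound 1 in this assay, 175 nM; 406 nM; 50 nM; 25 nM (4 entries). Among the measured compounds shown here, compound 2 `Cc1cc(C)c(CN2CCc3c(Cl)cc([C@H](CO)[C@H]4CCCO4)c(Cl)c3C2=O)c(=O)[nH]1` carries a hydroxymethyl in place of the methoxymethyl and a defined configuration at both stereocentres; in this assay compound 2 gives 63 nM, the only number it has here, with one further entry that gives no single number. Against the spread seen for compound 1, that value sits toward the lower end of the range covered by compound 1.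

Compound 3 `Cc1cc(C)c(CN2CCc3c(Cl)cc([C@@H](CO)[C@H]4CCCO4)c(Cl)c3C2=O)c(=O)[nH]1` is the next point. Its difference from compound 2: the two compounds have the same atoms and bonds and differ only in configuration as drawn: 1 of 2 stereo elements differ; a stereocentre at a saturated chain carbon is drawn R in compound 2 and S in compound 3. For the measured compounds named here, no measured pair in the set isolates such a change in configuration, so the size of the step is not known from the data. For a change at a single stereocentre in an otherwise identical molecule, a step to weaker inhibition of modest size is the expectation, though a step within the scatter cannot be excluded. The estimate for compound 3 in this assay is 150 nM, with a range of 40 nM to 600 nM, which corresponds to an expected step of a 2.4-fold higher number from compound 2 to compound 3 (0.38 log units; beyond the scatter).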

Compound 3, half-maximal inhibitory concentration: 535 nM
For compound 3 the middle estimate is 3.6-fold (0.55 log units) below the measured one; low and high end bracket the measured number.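

In this assay, among the compounds shown here, the change of a stereocentre at a saturated chain carbon from R to S gives the only step that can be read, an 8.5-fold higher number from compound 2 to compound 3 (0.93 log units; beyond the scatter). With nothing else changed, this step can be assigned to that one stereocentre: the fact that compounds 2 and 3 differ only in the configuration as drawn. Compound 1 could not show this, since it differs from compound 2 in more than one place and its repeats spread widely: the several entries of compound 1 in this assay, 175 nM; 406 nM; 50 nM; 25 nM (4 entries).

As far as these compounds go, it remains open whether R is also favoured at this stereocentre when the hydroxymethyl gives way to another group, such as an aminomethyl or a carboxylic acid. The second stereocentre is drawn the same in compound 2 and compound 3, so what its configuration contributes cannot be read from this pair.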